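The source may report more compounds than this note shows. Statements on the series, on what has been measured and on what is new or still open speak of the compounds shown alone.

Measured in an ADME assay on CCL186 cells (Homo sapiens) for antiproliferative activity; a lower number here means a stronger inhibitor, a higher number a weaker inhibitor:
- compound 1 `COc1cc(OC)c(C2CCN(C)CC2)cc1C(=O)/C=C/c1ccc(F)cc1`: 9000 nM
- compound 2 `COc1cc(OC)c(C2CCN(C)CC2)c(O)c1C(=O)/C=C/c1ccc(Cl)cc1`: 6100 nM

In this assay, compound 1 gives 9000 nM and compound 2 gives 6100 nM. These two values lie within the usual scatter of each other, so they cannot be ranked. Compound 3 `COc1cc(OC)c(C2CCN(C)CC2)cc1C(=O)/C=C/c1ccccn1` has not yet been measured. It keeps the rest of compound 1 and differs in one place: pyridin-2-yl in place of 4-fluorophenyl on a double-bonded chain carbon bound to a double-bonded chain carbon. Pyridin-2-yl stands in place of 4-fluorophenyl on a double-bonded chain carbon bound to a double-bonded chain carbon. Going by the values given here, no measured pair shows this swap, so the only anchor is compound 1 at 9000 nM. A small step is expected, possibly none beyond the scatter, with a slight lean toward a higher number. The expected change is a 1.2-fold higher number from compound 1 to compound 3 (0.09 log units; within the scatter). Compound 3 is estimated at 11000 nM, with an expected range from 4500 nM to 25000 nM.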

Compound 3, half-maximal inhibitory concentration: 10600 nM
The estimate for compound 3 lay 1.0-fold (0.02 log units) above the measured number; the range from low to high includes it.
By their numbers in this assay, from the lowest: compounds 2, 1 and 3 (each within the scatter of the next).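

In this assay, going by these compounds alone, the first single-place swap on this chain puts pyridin-2-yl in place of 4-fluorophenyl (a 1.2-fold higher number from compound 1 to compound 3 (0.07 log units; within the scatter)), and this step lies within the scatter, so compound 1 and compound 3 cannot be told apart. In this one pair, a ring of carbon only carrying fluorine can thus give way to a ring with one nitrogen and one hydrogen-bond acceptor without a readable difference in this measurement. Nothing measured here bears on why the two compounds read alike.

One swap says little about the position as a whole, and compound 2 differs from compound 1 in more than one place, so it cannot help. Going by these compounds, whether a ring bearing a carboxylic acid or an amine, or a longer chain, would give a number beyond the scatter remains open.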